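A few compounds are considered here, and "the series" means these few. Any claim that something is new, unique, unknown or untested is made for them only; others in the source may bear on it.

Measured so far in an ADME assay on NIH3T3 cells (Mus musculus) for cytotoxicity, read by MTT assay, with a stated time of 24 h; on this read-out lower numbers stand for stronger inhibition and higher numbers for weaker inhibition:
compound 1 `N#Cc1ccc(-c2cs/c(=N/NC(=O)CSc3ncccn3)n2-c2ccccc2)cc1` gives < 3.9 ug/mL, which is a limit of the assay rather than a number;
compound 2 `O=C(CSc1nnnn1-c1ccccc1)N/N=c1/scc(-c2ccc(Cl)cc2)n1-c1ccccc1` gives 313 ug/mL;
compound 3 `O=C(CSc1nnnn1-c1ccccc1)N/N=c1/scc(-c2ccc([N+](=O)[O-])cc2)n1-c1ccccc1` gives 14.3 ug/mL.

Among the two numbers, compound 2 stands highest, meaning the weakest inhibition of cell growth seen here. Its nearest neighbour is compound 3, and the step of a 22-fold lower number from compound 2 to compound 3 (1.34 log units; beyond the scatter) separates them. For compound 1 only the limit of < 3.9 ug/mL in this assay, at which 1 of the 3 values shown sits, is known.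

Compound 4 `O=C(CSc1ncccn1)N/N=c1/scc(-c2ccc(Cl)cc2)n1-c1ccccc1` has not yet been measured. It differs from compound 2 in one place: pyrimidin-2-yl in place of 1-phenyl-1H-tetrazol-5-yl on a sulfur. Going by the values given here, the single measured step, from compound 2 to compound 3, concerns a different part of the molecule and gives no direct guidance on exchanging the group on the sulfur. Among the compounds with values here, compound 1 is the only measured compound that carries pyrimidin-2-yl on its sulfur, but it differs from compound 4 elsewhere too. Within the data shown here, because compound 1 sits at the limit of < 3.9 ug/mL in this assay, at which 1 of the 3 values shown sits, no step can be computed from it. As far as these compounds go, the expectation for compound 4 therefore stays open, with a lean toward a lower number than compound 2, expected as a step of a 6.3-fold lower number from compound 2 to compound 4 (0.80 log units; beyond the scatter). The estimate for compound 4 in this assay is 50 ug/mL, with a likely range from 5 ug/mL to 300 ug/mL.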

Compound 4, half-maximal inhibitory concentration: 397 ug/mL
Compound 4: middle estimate off by 7.9-fold (0.90 log units), on the low side; the measured number lies above the stated range.
By their numbers in this assay, from the lowest: compound 3; then compounds 2 and 4 (each within the scatter of the next). At a limit, below all of these: compound 1.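

In this assay, going by these compounds alone, pyrimidin-2-yl in place of 1-phenyl-1H-tetrazol-5-yl on the sulfur gives a 1.3-fold higher number from compound 2 to compound 4 (0.10 log units; within the scatter), so with chloro on the aromatic carbon these two compounds cannot be told apart, even though the entering group has far fewer heavy atoms and only one ring. Pyrimidin-2-yl on the sulfur therefore does not by itself bring a low number: with that group held fixed, chloro in place of cyano on the aromatic carbon gives an at least 100-fold higher number from compound 1 to compound 4 (2.00 log units; beyond the scatter), a large step that shows the aromatic substituent can matter far more than the sulfur group in this pair of compounds. Compound 1 is a limit of the assay and not a number, and the step built on it gives only a minimum size: the limit of < 3.9 ug/mL in this assay, at which 1 of the 4 values shown sits.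

As far as these compounds go, it remains open whether a change on the aromatic carbon has the same size with both sulfur groups, as cyano appears here only with pyrimidin-2-yl and nitro only with 1-phenyl-1H-tetrazol-5-yl. The compounds shown also do not tell how a simple ethyl chain or a carboxylic acid on that sulfur would read.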